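The source may report more compounds than this note shows. Statements on the series, on what has been measured and on what is new or still open speak of the compounds shown alone.

Going by the values given here, compound 2 `CC(C)C[C@H](NC(=O)CN(c1nc(Cl)nc2[nH]cnc12)C1CC1)C(=O)OCc1ccccc1` stands at the low end of the two numbers so far: in a functional assay on the whole organism (Tail, strain ICR) with Mus musculus as the target, in the tail flick test, with a stated time of 150 min, at a dose of 25 umol/kg by the oral route (a lower number here means a weaker effect, a higher number a stronger effect of the compound at the dose given), compound 2 gives 5.26%, with compound 1 `CC[C@H](C)[C@H](NC(=O)CN(c1nc(Cl)nc2[nH]cnc12)C1CC1)C(=O)OCc1ccccc1` nearest, giving 6.9% in this assay, the step of a number 1.6 percentage points lower from compound 1 to compound 2 (within the scatter) lying within the scatter. Both values sit close to no effect at the dose given.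

Compound 3 `NC(=O)C[C@H](NC(=O)CN(c1nc(Cl)nc2[nH]cnc12)C1CC1)C(=O)OCc1ccccc1` differs from compound 2 in one place: carbamoyl in place of isopropyl on a saturated chain carbon, two bonds along the chain from an amide-type nitrogen and a carbonyl carbon. Among the compounds with values here, the only measured step, from compound 1 to compound 2, exchanged one saturated chain for another on the same part of the scaffold and moved the read-out hardly at all, as a number 1.6 percentage points lower from compound 1 to compound 2 (within the scatter) shows. Within the data shown here, it bears on the present change only in that the same position is being varied; no measured pair covers the exchange of a chain for a carbamoyl group, with its donor and acceptor, so the data give no direction for it. With both known values already low, the expectation is for a step from compound 2 to compound 3 of a number 0.7 percentage points higher from compound 2 to compound 3 (within the scatter) in this assay, that is, none beyond the scatter. Compound 3 is therefore estimated at 6% in this assay, within a range from 0% to 16%.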

Compound 3, a percentage reported as activity, at one dose (the size of the read-out at that dose, not a potency): 13.5%
Estimate against measurement, compound 3: 7.5 percentage points below; the range from low to high includes it.
By their numbers in this assay, from the lowest: compounds 2, 1 and 3 (each within the scatter of the next).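

In this assay, going by these compounds alone, the first change at this position that adds a hydrogen-bond donor and acceptor, carbamoyl in place of isopropyl, gives a number 8.2 percentage points higher from compound 2 to compound 3 (within the scatter), and the same compound set against the sec-butyl compound gives a number 6.6 percentage points higher from compound 1 to compound 3 (within the scatter). The carbamoyl-bearing side chain is therefore not separated from either all-carbon chain, so at this single dose and time the three compounds do not distinguish a side chain of carbon only from one with a carbamoyl group. No measurement at hand accounts for these numbers.

The compounds shown leave open whether a carboxylic acid, an amine or a longer chain ending in carbamoyl, on the saturated chain carbon bound to an amide-type nitrogen and a carbonyl carbon, would give a step beyond the scatter from these three. Also open, as far as these compounds go, is whether the three compounds would remain unseparated at another dose or another time in the same test.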